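The source may report more compounds than this note shows. Statements on the series, on what has been measured and on what is new or still open speak of the compounds shown alone.

Measured in a functional assay on MGC-803 cells (Homo sapiens) for inhibition, read by MTT assay, with a stated time of 48 h; on this read-out lower numbers stand for stronger inhibition and higher numbers for weaker inhibition:
- compound 1 `C/C=C/C(=O)N(Cc1ccc(OC)c([N+](=O)[O-])c1)c1cc(OC)c(OC)c(OC)c1`: 590 nM
- compound 2 `C/C=C/C(=O)N(Cc1ccc(OC)c(Br)c1)c1cc(OC)c(OC)c(OC)c1`: 6430 nM

In this assay, compound 2 stands at 6430 nM, the higher of the two numbers and so the weaker inhibitor of the pair. The next compound to be tested is compound 3 `C/C=C/C(=O)N(Cc1ccc(OC)c(C)c1)c1cc(OC)c(OC)c(OC)c1`. It keeps the shared core and changes one group: methyl in place of bromo on an aromatic carbon. Put simply, the 3-bromo-4-methoxyphenyl of compound 2 becomes the 4-methoxy-3-methylphenyl of compound 3.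

Within the data shown here, only one measured step bears on this change: an 11-fold higher number from compound 1 to compound 2 (1.04 log units; beyond the scatter), where bromo took the place of nitro. Among the measured compounds shown here, that step is large, but it says nothing direct about methyl, since no measured compound carries methyl at this carbon. The data therefore give no firm direction, and no step beyond the scatter is expected, though with real uncertainty. The expected change is a 1.3-fold lower number from compound 2 to compound 3 (0.11 log units; within the scatter). For compound 3, the estimated value is 5000 nM, with an expected range from 1200 nM to 20000 nM.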

Compound 3, half-maximal inhibitory concentration: 14500 nM
For compound 3 the middle estimate is 2.9-fold (0.46 log units) below the measured one; the measured number falls inside the stated range.
By their numbers in this assay, from the lowest: compound 1; then compound 2; then compound 3.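

In this assay, putting methyl in place of bromo on the aromatic carbon ortho to the methoxy group gives a 2.3-fold higher number from compound 2 to compound 3 (0.35 log units; beyond the scatter). This shows that even a swap of one heavy atom for one heavy atom, with no hydrogen-bond donor or acceptor on either side, can move the number beyond the scatter at this carbon. Methyl in place of nitro gives a 25-fold higher number from compound 1 to compound 3 (1.39 log units; beyond the scatter), so the three groups now fall into a clear order at this position, with nitro giving the strongest inhibition, bromo the middle result and methyl the weakest, although no supporting measurement is available to explain that order.

From the compounds shown here alone, three groups are too few to say what governs this position, and it remains open whether chloro, a nitrile or an amine on this carbon would come close to nitro or fall nearer to methyl. Going by these compounds, it is also open whether the same order would hold if the methoxy group were replaced by an ethoxy group.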